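Swapping the Carbamoyl Arm for a Cyanobenzyl Arm

A few compounds are considered here, and "the series" means these few. Any claim that something is new, unique, unknown or untested is made for them only; others in the source may bear on it.

Three compounds built on one shared core have been run through a functional assay on a cell-free system (plasma, Oryctolagus cuniculus) for inhibition, with stated times of 5 min, 1 min and 6 min; a higher number here means a weaker inhibitor, a lower number a stronger inhibitor. Compound 1, `CCOC(=O)c1c(C)nc(-c2cccc(C#N)c2)n1OC(C)C`, gives 6740 nM. Compound 2, `CCOCCOn1c(-c2cccc(C#N)c2)nc(C)c1C(=O)OCC`, gives 6250 nM. Compound 3, `CCOC(=O)c1c(C)nc(-c2cccc(C#N)c2)n1OCC(N)=O`, returns only a limit of the assay, > 30000 nM. The change a 1.1-fold lower number from compound 1 to compound 2 (0.03 log units; within the scatter) makes no real difference. The changes an at least 4.4-fold higher number from compound 1 to compound 3 (0.64 log units; beyond the scatter) and an at least 4.8-fold higher number from compound 2 to compound 3 (0.68 log units; beyond the scatter), by contrast, both weaken inhibition, so compound 3 stands at the weak end of the group, sitting at the limit of > 30000 nM in this assay, at which 1 of the 3 values shown sits, with no exact number known.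

Compound 4, `CCOC(=O)c1c(C)nc(-c2cccc(C#N)c2)n1OCc1ccc(C#N)cc1`, differs from compound 3 in one place: 4-cyanophenyl in place of carbamoyl on a saturated chain carbon bound to an oxygen on an aromatic ring.

Among the measured compounds shown here, the steps that bear on this are the two that led into compound 3, each at least modest in size and each pointing toward weaker inhibition when the carbamoyl arm entered. Compound 4 reverses that arm for a carbon-based aromatic group, and the two carbon-based arms of compounds 1 and 2 both sat well inside the measurable range. A step back toward those two values, at least modest in size and toward stronger inhibition, is therefore expected, though the limit leaves the starting point uncertain.

Compound 4 is estimated at 5000 nM, plausibly between 1500 nM and 30000 nM. That estimate means an expected step of an at least 6.0-fold lower number from compound 3 to compound 4 (0.77 log units; beyond the scatter).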

Compound 4, half-maximal inhibitory concentration: 4240 nM
Compound 4: middle estimate off by 1.2-fold (0.07 log units), on the high side; the range from low to high includes it.
By their numbers in this assay, from the lowest: compounds 4, 2 and 1 (each within the scatter of the next). At a limit, above all of these: compound 3.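

Replacing the carbamoyl arm in this assay with 4-cyanophenyl gives an at least 7.0-fold lower number from compound 3 to compound 4 (0.84 log units; beyond the scatter), which shows that the loss seen with compound 3 is not a penalty on every larger arm at this oxygen. Compound 3 is held at a limit rather than a number, so the size of this step is known only from one side: the limit of > 30000 nM in this assay, at which 1 of the 4 values shown sits. The other two steps, a 1.5-fold lower number from compound 2 to compound 4 (0.17 log units; within the scatter) and a 1.6-fold lower number from compound 1 to compound 4 (0.20 log units; within the scatter), are both within the scatter, so isopropyl, 2-ethoxyethyl and 4-cyanobenzyl cannot be told apart here, even though 4-cyanobenzyl brings in a six-membered aromatic ring of carbon only and a nitrile, and compound 3 alone goes against this flat picture.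

As far as these compounds go, how a carboxylic acid or an amine on that saturated chain carbon would read remains open, and with it whether the weak result belongs to carbamoyl alone or to a wider set of groups. Also open, from the compounds shown here alone, is whether the nitrile on the new ring matters at all, which a plain benzyl arm on the same oxygen would test, and whether any arm here can move the number beyond the scatter of compounds 1, 2 and 4.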